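Compound 3: a smaller sulfanyl group on the chain carbon

This account rests on a few compounds, and the source may have more. Where it says the series, first, only, none or still open, it means among the compounds named here.

Compound 1 `OC[C@H]1O[C@@H](n2cnc3c(CSCc4ccccc4)ncnc32)[C@H](O)[C@@H]1O`: > 100000 nM (a limit)
Compound 2 `OC[C@H]1O[C@@H](n2cnc3c(COc4ccccn4)ncnc32)[C@H](O)[C@@H]1O`: > 250000 nM (a limit)

In a functional assay on Huh-7 cells (Homo sapiens) for cytotoxicity, read by MTT assay, with a stated time of 3 days (a lower number here means that less compound is tolerated, a higher number that more compound is tolerated), compound 2 gives only a limit, > 250000 nM. Among the measured compounds shown here, the only other value available is also a limit.

Compound 3 `CSCc1ncnc2c1ncn2[C@@H]1O[C@H](CO)[C@@H](O)[C@H]1O` has methylsulfanyl in place of (pyridin-2-yl)oxy on a saturated chain carbon bound to an aromatic carbon.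

For the measured compounds named here, the one measured step that bears on this change is a step that the two limits leave unreadable from compound 1 to compound 2, so no measured size is available. Compound 1 carries benzylsulfanyl at that place, and its value of > 100000 nM is a limit. On this loose ground, the expected change in this assay is an at least 3.1-fold lower number from compound 2 to compound 3 (0.49 log units; beyond the scatter), toward a lower number. For compound 3 the estimate is 80000 nM, with an expected range of 8000 nM to 250000 nM.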

Compound 3, half-maximal cytotoxic concentration: > 100000 nM
Compound 3 gave a limit, no number; the forecaster's own chance of this, stated with the estimate: 60%; middle value at least 1.2-fold (0.09 log units) from the limit.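

Among the compounds shown here, compound 1, compound 2 and compound 3 all give only limits in this assay, and no step among them can be read. The compounds shown leave open whether any group at this place gives a half-maximal cytotoxic concentration that can be read as a number.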